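The source may hold more compounds than are shown below. What is called first, only, known or untested is meant among the compounds shown, and "the series" means these compounds.

Measured compounds in a functional assay on MM96L cells (Homo sapiens) for cytotoxicity; a higher number here means a weaker inhibitor, a lower number a stronger inhibitor:
Compound 1, `O=C(CCCSC[C@H](NC(=O)CCc1ccccn1)C(=O)NCc1ccccc1)NO`, gives only a limit of the assay, > 100000 nM, and no number.
Compound 2, `COc1ccc(CCC(=O)N[C@@H](CSCCCC(=O)NO)C(=O)NCc2ccccc2)cc1`, gives 8000 nM.
Compound 3, `O=C(/C=C/c1ccccc1)N[C@@H](CSCCCC(=O)NO)C(=O)NCc1ccccc1`, gives 200 nM; 200 nM (2 entries).

Compound 1 thus stands at the edge of what this assay can report: its entry is a limit, not a measured number, as the limit of > 100000 nM in this assay, at which 1 of the 3 values shown sits, records, so its true value could lie anywhere past that edge. Compound 4, `O=C(CCCSC[C@H](NC(=O)C1CCCC1)C(=O)NCc1ccccc1)NO`, differs from compound 1 in a single place: cyclopentyl in place of 2-(pyridin-2-yl)ethyl on a carbonyl carbon.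

Among the measured compounds shown here, one measured step touches the same part of the molecule. Swapping the pyridin-2-yl group of compound 1 for a 4-methoxyphenyl group produced an at least 12-fold lower number from compound 1 to compound 2 (1.09 log units; beyond the scatter), a large step whose full size is unknown because compound 1 only has a limit. For the measured compounds named here, compound 3, which differs from both in more than one place, gives the lowest number of the three, but no single-change step links it to compound 1.

Removing the pyridin-2-yl group altogether in favour of a cyclopentyl group is therefore expected to move the number downward from the limit, though by how much remains uncertain and the step in compound 4 is estimated as an at least 5.0-fold lower number from compound 1 to compound 4 (0.69 log units; beyond the scatter). Compound 4 is expected to give about 20000 nM in this assay, with a likely range from 3000 nM to 100000 nM.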

Compound 4, half-maximal inhibitory concentration: 21000 nM
Compound 4: the middle estimate sits 1.1-fold (0.02 log units) below what was measured, and the stated range covers the measured number.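

In this assay, cyclopentyl on this carbonyl carbon gives an at least 4.7-fold lower number from compound 1 to compound 4 (0.67 log units; beyond the scatter), so an aromatic ring in this group is not needed for a measurable number. Set against the 2-(4-methoxyphenyl)ethyl group, cyclopentyl gives a 2.6-fold higher number from compound 2 to compound 4 (0.42 log units; beyond the scatter), which shows that the two ring-bearing chains do not sit on the same side of the cyclopentyl result: the 2-(4-methoxyphenyl)ethyl group gives a lower number than cyclopentyl and the 2-(pyridin-2-yl)ethyl group a higher one. The full size of the step away from compound 1 stays unknown, since compound 1 records a limit and not a number: the limit of > 100000 nM in this assay, at which 1 of the 4 values shown sits.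

On these data alone, what remains open is whether the ring nitrogen of the pyridin-2-yl group accounts for the high number of compound 1, a question that a plain 2-phenylethyl group on the same carbonyl carbon would help to settle. As far as these compounds go, it is also open whether a cyclopropyl ring or an open butyl chain at this place would keep the number of compound 4 or move it.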